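Removing an Amide Side Chain on Two Related Cores

A few compounds are considered here, and "the series" means these few. Any claim that something is new, unique, unknown or untested is made for them only; others in the source may bear on it.

The study compares three measured compounds in a physicochemical assay for lipophilicity, using the shake flask method; a higher number here means a more lipophilic compound, a lower number a more polar compound. Compound 3 `C[C@H](Oc1ccc(NC(=O)CC(N)=O)c(C2CC2)c1)c1c(Cl)ccc(F)c1Cl` carries a ((carbamoylmethyl)carbonyl)amino group on an aromatic carbon of a six-membered aromatic ring of carbon only, and in this assay compound 3 gives 3.9. Compound 2 `C[C@H](Oc1cccc(C2CC2)c1)c1c(Cl)ccc(F)c1Cl` lacks that group; in this assay compound 2 gives 5. The change between them is hydrogen in place of ((carbamoylmethyl)carbonyl)amino on an aromatic carbon, and it produced a number 1.10 log units higher from compound 3 to compound 2 (beyond the scatter).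

Compound 1 `C[C@H](Oc1ccc(NC(=O)CC(N)=O)c(C2CC2)n1)c1c(Cl)ccc(F)c1Cl` carries the same ((carbamoylmethyl)carbonyl)amino group on a six-membered aromatic ring with 1 nitrogen, and in this assay compound 1 gives 3.7. Set beside compound 3, this number lies within the usual scatter of the method, so no order between the two can be claimed. How the core of compound 1 differs from the core of compound 3 is not broken down here.

Compound 4 `C[C@H](Oc1cccc(C2CC2)n1)c1c(Cl)ccc(F)c1Cl` has not yet been measured. It stands to compound 1 as compound 2 stands to compound 3: hydrogen in place of ((carbamoylmethyl)carbonyl)amino on an aromatic carbon. The surroundings are not identical, since in compound 1 the group sits on a six-membered aromatic ring with 1 nitrogen, two atoms from the ring nitrogen, whereas in compound 3 it sits on a ring of carbon only; this is therefore the same kind of change, not the same change. Because the same kind of change gave a number 1.10 log units higher from compound 3 to compound 2 (beyond the scatter), the step from compound 1 to compound 4 is expected to be a number 1.10 log units higher from compound 1 to compound 4 (beyond the scatter). For compound 4 the expected value in this assay is 4.8, with a range from 4.3 to 5.3.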

Compound 4, distribution coefficient: 4.9
The estimate for compound 4 lay 0.10 log units below the measured number; the range from low to high includes it.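

In this assay, putting hydrogen in place of the ((carbamoylmethyl)carbonyl)amino group gave a number 1.20 log units higher from compound 1 to compound 4 (beyond the scatter), while the same kind of change on the other core gave a number 1.10 log units higher from compound 3 to compound 2 (beyond the scatter), so the step ran the same way and reached much the same size on both cores. This shows that, for these two cores and this one read-out, the size of the step on the core of compound 3 carried over well to the core of compound 1, but two pairs of compounds establish no rule for other cores, other positions on the ring or other assays. Nothing given here bears on what lies behind the size of the step on either core.

The compounds shown leave open whether the step belongs to the whole ((carbamoylmethyl)carbonyl)amino group or mainly to a part of it, which a plain amine, a simple acetamide or a carboxylic acid in its place could help to separate. They also leave open whether a longer chain ending in the same amide, or a methyl group in place of the cyclopropyl group, would keep the step at a similar size on both cores.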